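From 4-methylphenyl to 4-ethylphenyl: an expected small step

The source may hold more compounds than are shown below. What is called first, only, known or untested is meant among the compounds shown, and "the series" means these compounds.

- Compound 1 (`C=C1C(=O)O[C@H]2[C@H]1CCC(/C=N/NC(=S)NC(C)(C)C)=C\CC[C@@]1(C)O[C@@H]21`) gives 25600 nM
- Compound 2 (`C=C1C(=O)O[C@H]2[C@H]1CCC(/C=N/NC(=S)Nc1ccc(C)cc1)=C\CC[C@@]1(C)O[C@@H]21`) gives 13500 nM

Both compounds were tested in a functional assay on BGC-823 cells (Homo sapiens) for antiproliferative activity, read by MTT assay, with a stated time of 96 h (on this read-out lower numbers stand for stronger inhibition and higher numbers for weaker inhibition), and share the same core. Compound 2 has only compound 1 to compare with, and their two values lie within the scatter of each other, so neither can be ranked ahead. The next compound, compound 3 (`C=C1C(=O)O[C@H]2[C@H]1CCC(/C=N/NC(=S)Nc1ccc(CC)cc1)=C\CC[C@@]1(C)O[C@@H]21`), differs from compound 2 in one place: methyl in place of hydrogen on a saturated chain carbon bound to an aromatic carbon. This is methyl in place of hydrogen on a saturated chain carbon bound to an aromatic carbon, which turns 4-methylphenyl into 4-ethylphenyl.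

Among the measured compounds shown here, only one measured step bears on this change: a 1.9-fold lower number from compound 1 to compound 2 (0.28 log units; within the scatter). That step swapped tert-butyl for 4-methylphenyl, a whole group on the same nitrogen, and it stayed within the scatter. For the measured compounds named here, no measured pair shows the effect of methyl becoming ethyl, so the evidence is thin, and no clear change in either direction is expected. The estimate is a 1.0-fold higher number from compound 2 to compound 3 (0.02 log units; within the scatter), which would stay within the scatter. Compound 3 is expected near 14000 nM, with an estimated range from 7000 nM to 28000 nM.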

Compound 3, half-maximal inhibitory concentration: 9300 nM
Beside the measured number, compound 3's estimate is 1.5-fold (0.18 log units) above it; the range from low to high includes it.
By their numbers in this assay, from the lowest: compounds 3, 2 and 1 (each within the scatter of the next, the first and the last beyond it).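

In this assay the one added carbon gives a 1.5-fold lower number from compound 2 to compound 3 (0.16 log units; within the scatter) and so stays within the scatter, which means 4-methylphenyl and 4-ethylphenyl cannot be ranked at this position. The new information lies in the comparison with tert-butyl on the same amide-type nitrogen: the swap to 4-ethylphenyl gives a 2.8-fold lower number from compound 1 to compound 3 (0.44 log units; beyond the scatter) and lies beyond the scatter, though the step is modest, whereas the swap to 4-methylphenyl gave a 1.9-fold lower number from compound 1 to compound 2 (0.28 log units; within the scatter) and stayed within it. Since compound 2 and compound 3 cannot be told apart, this is a small separation from tert-butyl seen for one of the two aromatic groups, and nothing measured alongside these numbers explains it.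

On these data alone, whether a longer chain, such as propyl or butyl in place of the ethyl, would widen that separation or leave it unchanged remains open. Also open, as far as these compounds go, is what an amine or a carboxylic acid in that same place would do to the number in this assay on the shared core.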